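The source may hold more compounds than are shown below. What is called first, only, known or untested is meant among the compounds shown, and "the series" means these compounds.

Of the compounds shown here, two have so far been measured in an assay on MDA-MB-231 cells for displacement of a labelled ligand from C-X-C chemokine receptor type 4 (Homo sapiens), read by fluorescence and microscopy, with stated times of 10 min and 30 min; a lower number here means that less compound is needed, a higher number that more compound is needed for the effect. Compound 1 `Cc1ccccc1C(=O)NCc1ccc(CNS(=O)(=O)c2ccc(Cl)cc2)cc1` gives 1 nM, and compound 2 `COc1ccccc1C(=O)NCc1ccc(CNS(=O)(=O)c2ccc([N+](=O)[O-])cc2)cc1` gives 100 nM, the higher of the two numbers, with compound 1 standing well below it, beyond the scatter. Going by the values given here, these two compounds differ in more than one place, so no single step links them. Among the compounds with values here, compound 3 `Cc1ccccc1C(=O)NCc1ccc(CNS(=O)(=O)c2ccc([N+](=O)[O-])cc2)cc1` keeps the rest of compound 2 unchanged and alters only one group: methyl in place of methoxy on an aromatic carbon. This change moves toward the group found in compound 1. The step is expected to be a 5.0-fold lower number from compound 2 to compound 3 (0.70 log units; beyond the scatter), toward a lower number. Compound 3 is estimated at 20 nM, with a range from 3 nM to 150 nM.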

Compound 3, effective concentration (reported as EC, without a stated level of effect): 100 nM
Compound 3: the middle estimate sits 5.0-fold (0.70 log units) below what was measured; the range from low to high includes it.
By their numbers in this assay, from the lowest: compound 1; then compounds 2 and 3 (each within the scatter of the next).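

In this assay, methyl in place of methoxy on the aromatic carbon ortho to a large group gives no change at the digits printed from compound 2 to compound 3 (within the scatter), so with nitro present, this position does not separate these two groups. Nitro in place of chloro gives a 100-fold higher number from compound 1 to compound 3 (2.00 log units; beyond the scatter), which places a large step on that single change. Nothing shown explains either result.

Going by these compounds, it remains open whether methyl and methoxy would also match alongside chloro, and how an amine or a carboxylic acid would behave at the same carbon.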